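This account rests on a few compounds, and the source may have more. Where it says the series, first, only, none or still open, it means among the compounds named here.

Measured compounds in an ADME assay on NIH3T3 cells (Mus musculus) for cytotoxicity, with a stated time of 72 h; on this read-out lower numbers stand for stronger inhibition and higher numbers for weaker inhibition:
compound 1, `OC[C@H]1O[C@@H](n2cnc3c(NCc4ccccc4F)ncnc32)[C@H](O)[C@@H]1O`, gives > 166000 nM, a limit of the assay.
compound 2, `OC[C@H]1O[C@@H](n2cnc3c(NCc4ccc(F)cc4)ncnc32)[C@H](O)[C@@H]1O`, gives 44300 nM.
compound 3, `OC[C@H]1O[C@@H](n2cnc3c(NCc4ccc(Cl)cc4)ncnc32)[C@H](O)[C@@H]1O`, gives > 166000 nM, likewise a limit.

Compound 3 therefore stands at the limit of > 166000 nM in this assay, at which 2 of the 3 values shown sit, with no number of its own. Compound 4, `Cc1ccc(CNc2ncnc3c2ncn3[C@@H]2O[C@H](CO)[C@@H](O)[C@H]2O)cc1`, differs from compound 3 by methyl in place of chloro on an aromatic carbon. Among the measured compounds shown here, no measured step swaps chloro for methyl; the nearest is an at least 3.7-fold higher number from compound 2 to compound 3 (0.57 log units; beyond the scatter), while an at least 3.7-fold lower number from compound 1 to compound 2 (0.57 log units; beyond the scatter) concerns ring position and a step that the two limits leave unreadable from compound 1 to compound 3. With two of three values at the limit, a small change in this assay is expected: compound 4 is estimated at 120000 nM, range 40000 nM to 300000 nM. For compound 4 this means an expected at least 1.3-fold lower number from compound 3 to compound 4 (0.14 log units; that floor lies within the scatter), with a fair chance of another limit.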

Compound 4, half-maximal inhibitory concentration: > 166000 nM
Compound 4 was reported as a limit; the forecaster's own chance of this, stated with the estimate: 50%; middle value at least 1.3-fold (0.14 log units) from the limit.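

Methyl in place of fluoro on the aromatic carbon gives an at least 3.7-fold higher number from compound 2 to compound 4 (0.57 log units; beyond the scatter), so a second replacement of fluoro at this place, after chloro in compound 3, moves the number the same way in this assay. The steps from compound 3 and from compound 1 to compound 4 cannot be read, since both ends are limits. Compound 2 remains the only compound with a number of its own: the limit of > 166000 nM in this assay, at which 3 of the 4 values shown sit.

On these data alone, whether a methoxy group or an amine at this place gives a measured number stays open. So does how a longer chain in place of the benzyl group would read.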